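The source may hold more compounds than are shown below. What is called first, only, known or untested is meant among the compounds shown, and "the series" means these compounds.

Measured compounds:
Compound 1 `CC(C)(CCN(C[C@H]1Cc2ccccc2CN1)[C@H]1CCCc2cccnc21)CNCC1CCOCC1` gives 43.8 nM in a functional assay on cells for antagonist activity at C-X-C chemokine receptor type 4 (Homo sapiens), read by fluorescence and calcium flux, with stated times of 25 min and 90 s; a lower number here means a stronger inhibitor, a higher number a weaker inhibitor.
Compound 2 `CC(C)(CCN(C[C@H]1Cc2ccccc2CN1)[C@H]1CCCc2cccnc21)CNC1CCOCC1` gives 36.3 nM in this assay.

Among the compounds with values here, compound 2 has the lower of the two numbers, but the only measured step, a 1.2-fold lower number from compound 1 to compound 2 (0.08 log units; within the scatter), is within the scatter, so the two compounds cannot be told apart on these data. Compound 3 `CC1(C)CCC(NCC(C)(C)CCN(C[C@H]2Cc3ccccc3CN2)[C@H]2CCCc3cccnc32)CC1` differs from compound 2 in one place: 4,4-dimethylcyclohexyl in place of oxan-4-yl on an amine nitrogen. Within the data shown here, the one measured step bears on it only loosely, since it concerns the same amine nitrogen but exchanges a linker rather than the ring itself, and it was too small to show a trend. Among the measured compounds shown here, no measured compound shows what the loss of the ring oxygen or the added dimethyl group does here. Compound 3 is therefore expected to sit close to compound 2, with an estimated step of a 1.2-fold lower number from compound 2 to compound 3 (0.08 log units; within the scatter). Compound 3 is estimated at 30 nM, in the range 10 nM to 100 nM.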

Compound 3, half-maximal inhibitory concentration in the C-X-C chemokine receptor type 4 assay: 541 nM
The estimate for compound 3 lay 18-fold (1.26 log units) below the measured number; measured number above the stated range.
By their numbers in the C-X-C chemokine receptor type 4 assay, from the lowest: compounds 2 and 1 (each within the scatter of the next); then compound 3.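

In the C-X-C chemokine receptor type 4 assay, this amine nitrogen proves sensitive to the group it carries: 4,4-dimethylcyclohexyl in place of oxan-4-yl gives a 15-fold higher number from compound 2 to compound 3 (1.17 log units; beyond the scatter), and in place of (oxan-4-yl)methyl it gives a 12-fold higher number from compound 1 to compound 3 (1.09 log units; beyond the scatter). The two oxygen-containing groups could not be told apart, so the position accepts that difference in linker but not this exchange of ring. In a physicochemical assay for permeability, using PAMPA, with a stated time of 4 h, at pH 7.4, tested at 100 uM (on this read-out lower numbers stand for lower permeability and higher numbers for higher permeability), compound 2 gives 57 nm/s and compound 3 gives 28 nm/s. The same exchange thus also lowers the measured permeability, so the carbon-only ring gains no advantage on that read-out: the measured apparent permeability of compound 2, 57 nm/s, and of compound 3, 28 nm/s, a 2.0-fold lower number (0.31 log units; beyond the scatter)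

The compounds shown do not separate the loss of the ring oxygen from the addition of the two methyl groups. An unsubstituted cyclohexyl group or a 2,2-dimethyloxan-4-yl group on this nitrogen would bear on that question.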